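Working notes: whole-organism cytotoxicity across three aryl variants

The source may report more compounds than this note shows. Statements on the series, on what has been measured and on what is new or still open speak of the compounds shown alone.

Measured so far:
- compound 1 `Cc1ccc(S(=O)(=O)NC(=O)Nc2ccccc2C(=O)/C=C/c2ccccc2O)cc1`: 32.3 ug/mL
- compound 2 `Cc1ccc(S(=O)(=O)NC(=O)Nc2ccccc2C(=O)/C=C/c2cccc(F)c2)cc1`: 4.13 ug/mL

Both numbers come from an ADME assay on the whole organism for cytotoxicity, with Artemia salina as the target, with a stated time of 24 h; on this read-out lower numbers stand for an effect already at smaller amounts and higher numbers for an effect only at larger amounts of compound. Among the compounds with values here, compound 2 holds the lowest of the two numbers; its nearest neighbour is compound 1, and the only step between measured compounds is a 7.8-fold lower number from compound 1 to compound 2 (0.89 log units; beyond the scatter).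

Compound 3 `Cc1ccc(S(=O)(=O)NC(=O)Nc2ccccc2C(=O)/C=C/c2ccc(Cl)cc2)cc1` is not yet measured. It differs from compound 2 in one place: 4-chlorophenyl in place of 3-fluorophenyl on a double-bonded chain carbon bound to a double-bonded chain carbon.

Which measured steps bear on this change? Strictly none directly: the single step from compound 1 to compound 2 swaps a hydroxylated ring for a fluorinated one, whereas the step to compound 3 swaps one halogenated ring for another. That earlier step was modest in size and went downward, so the read-out does respond to what sits on this ring. With no halogen-for-halogen comparison in hand, the expectation for compound 3 is a number close to that of compound 2, with a 1.1-fold higher number from compound 2 to compound 3 (0.04 log units; within the scatter) not clearly beyond the scatter. Compound 3 is therefore estimated at 4.5 ug/mL, within 1.5 ug/mL to 14 ug/mL.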

Compound 3, concentration for half-maximal effect: 6.92 ug/mL
Compound 3: middle estimate off by 1.5-fold (0.19 log units), on the low side; measured number inside the range.
By their numbers in this assay, from the lowest: compounds 2 and 3 (each within the scatter of the next); then compound 1.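

In this assay, within the data shown here, the first comparison of one halogenated ring with another gives a 1.7-fold higher number from compound 2 to compound 3 (0.22 log units; within the scatter), so 3-fluorophenyl and 4-chlorophenyl on a double-bonded chain carbon bound to a double-bonded chain carbon cannot be told apart on this read-out. The replacement of the hydroxylated ring gives a 4.7-fold lower number from compound 1 to compound 3 (0.67 log units; beyond the scatter), and with the earlier 7.8-fold lower number from compound 1 to compound 2 (0.89 log units; beyond the scatter) as a second case, both halogenated rings now stand apart from the 2-hydroxyphenyl of compound 1, a split that holds for these three compounds with none going against it. Nothing measured here bears on why the read-out divides in this way.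

The step from compound 2 to compound 3 changes the halogen and its place on the ring together, so a shift from one could be masked by the other, and neither can be read alone. As far as these compounds go, it also remains open whether a ring carrying an amine, a carboxylic acid or a methoxy group would fall with compound 2 and compound 3 or with compound 1, and whether the hydroxyl group itself sets compound 1 apart.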